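The source may hold more compounds than are shown below. What is called first, only, known or untested is meant among the compounds shown, and "the series" means these compounds.

Measured so far:
compound 1 `Clc1ccccc1Cn1ccc2nc(-c3ccccc3)nc-2c1` — > 100000 nM
compound 2 `FC(F)(F)c1ccc(Cn2ccc3nc(-c4ccccc4)nc-3c2)cc1` — 84000 nM

In an ADME assay on MDBK cells (Bos taurus) for cytotoxicity (on this read-out higher numbers stand for lower toxicity in this test and lower numbers for higher toxicity in this test), compound 1 gives > 100000 nM, which is a limit of the assay and not a number. In this assay compound 2 gives 84000 nM. Among the compounds with values here, both readings sit at the low-toxicity end of the read-out, and the only firm evidence on the series is the limit of > 100000 nM in this assay, at which 1 of the 2 values shown sits. Compound 1 therefore stands at a limit, with no number to rank it against compound 2.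

Compound 3 `Clc1ccc(Cn2ccc3nc(-c4ccccc4)nc-3c2)s1` has not yet been measured. It differs from compound 1 by 5-chlorothiophen-2-yl in place of 2-chlorophenyl on a saturated chain carbon bound to an aromatic nitrogen. Within the data shown here, no measured pair carries this change, so the size of the step cannot be read from the data. The expectation is a step of no size beyond the scatter, in either direction, as an at least 1.1-fold lower number from compound 1 to compound 3 (0.04 log units; that floor lies within the scatter). For compound 3 the estimated value in this assay is 90000 nM, expected to fall between 40000 nM and 200000 nM.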

Compound 3, half-maximal cytotoxic concentration: > 100000 nM
Compound 3: a limit, no number (the forecaster's own chance of this, stated with the estimate: 45%); middle value at least 1.1-fold (0.04 log units) from the limit.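

No step can be read from compound 1 to compound 3 in this assay, because both values are limits of the assay and not numbers: the limit of > 100000 nM in this assay, at which 2 of the 3 values shown sit.

The compounds shown leave open whether 5-chlorothiophen-2-yl in place of 2-chlorophenyl shifts the read-out at all.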